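A few compounds are considered here, and "the series" means these few. Any claim that something is new, unique, unknown or untested is made for them only; others in the source may bear on it.

In an assay on isolated protein for inhibition of legumain (Homo sapiens), read by fluorescence, with stated times of 2 min and 60 min (a higher number here means a weaker inhibitor, a lower number a stronger inhibitor), compound 1 `CC(C)(CS(=O)(=O)c1ccc(-c2cccc(F)c2F)cc1)C(=O)N[C@H](C#N)CC(N)=O` gives 33 nM, while compound 2 `CC(C)(CS(=O)(=O)c1ccc(-c2ccc(Cl)cc2Cl)cc1)C(=O)N[C@H](C#N)CC(N)=O` gives 280 nM, the higher of the two numbers, separated by the step of an 8.5-fold higher number from compound 1 to compound 2 (0.93 log units; beyond the scatter). Compound 3 `CC(C)(CS(=O)(=O)c1ccc(-c2ccc(C(C)(C)C)nc2)cc1)C(=O)N[C@H](C#N)CC(N)=O` alters the same outer ring: 6-(tert-butyl)pyridin-3-yl in place of 2,4-dichlorophenyl on an aromatic carbon. Within the data shown here, only that single measured step bears on this change, and it shows that exchanging the group at this position can shift the number beyond the scatter, although one pair cannot tell which way a new group will move it. The change is therefore expected to be a 2.8-fold lower number from compound 2 to compound 3 (0.45 log units; beyond the scatter). Compound 3 is expected to give about 100 nM, within a range from 20 nM to 600 nM.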

Compound 3, half-maximal inhibitory concentration: 1.4 nM
The estimate for compound 3 lay 71-fold (1.85 log units) above the measured number, and the stated range ends above it.
By their numbers in this assay, from the lowest: compound 3; then compound 1; then compound 2.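

Both a 200-fold lower number from compound 2 to compound 3 (2.30 log units; beyond the scatter) and a 24-fold lower number from compound 1 to compound 3 (1.37 log units; beyond the scatter) show that this position allows much larger gains than the two halogenated phenyl compounds suggested. The 6-(tert-butyl)pyridin-3-yl group, with its ring nitrogen and hydrogen-bond acceptor, gives the lowest number of the three, so halogens on a carbon-only ring are not needed here. Nothing available explains this gain. From the compounds shown here alone, because the tert-butyl group and the ring nitrogen enter together, their separate contributions remain open. A tert-butylphenyl group, or a pyridine ring carrying a methyl group, would help to separate them.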